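This account rests on a few compounds, and the source may have more. Where it says the series, first, only, none or still open, it means among the compounds named here.

The measured compounds in a functional assay on MDA-MB-231 cells (Homo sapiens) for cytotoxicity, read by sulforhodamine B assay, with a stated time of 48 h; a higher number here means a weaker inhibitor of growth, a lower number a stronger inhibitor of growth:
- compound 1 `CCN(CC)CN1C(=O)/C(=N\c2nc3ccc(C)cc3s2)c2ccccc21` gives 32700 nM
- compound 2 `CCN(CC)CN1C(=O)/C(=N\c2nc3ccc(C)cc3s2)c2c(Br)cccc21` gives 28700 nM
- compound 3 `CN(C)CN1C(=O)C(=O)c2c(Br)cccc21` gives 93700 nM

Among these three numbers compound 1 stands second highest: compound 2 is nearest, with a 1.1-fold lower number from compound 1 to compound 2 (0.06 log units; within the scatter), while compound 3 is furthest, its number lying beyond the scatter above that of compound 1.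

Compound 4 `Cc1ccc2nc(/N=C3\C(=O)N(CN(C)C)c4ccccc43)sc2c1` is not yet measured. It differs from compound 1 in one place: dimethylamino in place of diethylamino on a saturated chain carbon bound to an amide-type nitrogen in a ring. Among the measured compounds shown here, no measured step in this set bears directly on that change. For the measured compounds named here, the only single-point step, from compound 1 to compound 2, concerns a bromo group and was within the scatter. Compound 3 does carry the dimethylamino group, but it differs from compounds 1 and 2 in more than one place, so its higher number cannot be tied to that group alone.

Going by the values given here, with no direct precedent, compound 4 is expected to fall close to compound 1, with the step of a 1.1-fold higher number from compound 1 to compound 4 (0.03 log units; within the scatter) expected to lie within the scatter. Compound 4 is therefore estimated at 35000 nM, in a range from 15000 nM to 80000 nM.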

Compound 4, concentration for 50% growth inhibition: 19200 nM
Compound 4: the middle estimate sits 1.8-fold (0.26 log units) above what was measured, within the range that was stated.
By their numbers in this assay, from the lowest: compounds 4, 2 and 1 (each within the scatter of the next); then compound 3.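

In this assay, the change of diethylamino to dimethylamino on a saturated chain carbon bound to an amide-type nitrogen in a ring now has a direct reading: a 1.7-fold lower number from compound 1 to compound 4 (0.23 log units; within the scatter). Among the compounds shown here, this is the first single-place step at this position, and it shows that on the core of compound 1 the two groups cannot be told apart in this assay. Nothing available accounts for this result, and no measurement on either group accompanies it.

The compounds shown leave open whether dipropylamino or a primary amine in the same place would give a step beyond the scatter. They also leave open whether the same exchange of diethylamino for dimethylamino would read alike on the bromo-bearing core of compound 2.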